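Moving the methyl on the anilino ring of compound 3

This account rests on a few compounds, and the source may have more. Where it says the series, first, only, none or still open, it means among the compounds named here.

Compound 1 `C#CCSc1nc(Nc2ccccc2Cl)c(C#N)c(-c2ccccc2)n1` gives > 128000 nM in a functional assay on ECa-109 cells (Homo sapiens) for inhibition, read by MTT assay, with a stated time of 72 h (on this read-out lower numbers stand for stronger inhibition and higher numbers for weaker inhibition), which is a limit of the assay rather than a number.
Compound 2 `Cc1ccccc1Nc1nc(SCc2cn(Cc3ccccc3Cl)nn2)nc(-c2ccccc2)c1C#N` gives 9740 nM in this assay.
Compound 3 `Cc1ccc(Cn2cc(CSc3nc(Nc4ccccc4C)c(C#N)c(-c4ccccc4)n3)nn2)cc1` gives > 64000 nM in this assay, again a limit of the assay rather than a number.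

Compound 3 therefore stands at a limit of this assay (the limit of > 64000 nM in this assay, at which 1 of the 3 values shown sits), so its inhibition is known only to be weaker than the assay can put a number on. Compound 1 sits at a limit as well (the limit of > 128000 nM in this assay, at which 1 of the 3 values shown sits). Among the compounds with values here, compound 2 is the only one of the three with a measured number, and the single measured step, an at least 6.5-fold higher number from compound 2 to compound 3 (0.81 log units; beyond the scatter), already led from a number to a limit.

Compound 4 `Cc1ccc(Cn2cc(CSc3nc(Nc4ccc(C)cc4)c(C#N)c(-c4ccccc4)n3)nn2)cc1` differs from compound 3 by 4-methylphenyl in place of 2-methylphenyl on a nitrogen on an aromatic ring. Within the data shown here, no measured step bears on this change: the step of an at least 6.5-fold higher number from compound 2 to compound 3 (0.81 log units; beyond the scatter) concerns the group on the saturated chain carbon bound to the aromatic nitrogen, not the group on the nitrogen on the aromatic ring. Among the measured compounds shown here, since compound 3 is already at a limit and nothing among the measured compounds shows the effect of this change, compound 4 is expected to remain about as weak, with an estimated value of 80000 nM, ranging from 25000 nM to 200000 nM. This estimate corresponds to an expected step that the limit leaves unreadable from compound 3 to compound 4, most likely reported again as a limit.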

Compound 4, half-maximal inhibitory concentration: 55700 nM
Compound 4: middle estimate off by 1.4-fold (0.16 log units), on the high side; the range from low to high includes it.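

Putting 4-methylphenyl in place of 2-methylphenyl on the nitrogen gives, in this assay, an at least 1.1-fold lower number from compound 3 to compound 4 (0.06 log units; that floor lies within the scatter). Only this floor can be read, because compound 3 stands at a limit of the assay and not at a number: the limit of > 64000 nM in this assay, at which 1 of the 4 values shown sits. Within the data shown here, what the new compound adds is a first measured number for this change, as compound 4 gives 55700 nM, yet the true size of the change remains unknown and could be small or large.

The compounds shown leave open whether the methyl on this ring matters at all, since the ring is compared only with a methyl in two places, and a plain phenyl, or a ring carrying a methoxy group or an amine, would test that directly. They also leave open whether (4-methylphenyl)amino behaves the same way when the group on the saturated chain carbon is 2-chlorophenyl, the group carried by compound 2, which gives 9740 nM.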